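Ring to open chain: the step from compound 1

The compounds below may be only part of what the source reports. "The series", "measured", "known", "first", "only" and "open" are said of these compounds alone.

Values from a functional assay on MCF7 cells (Homo sapiens) for inhibition, read by sulforhodamine B assay, with a stated time of 48 h (a lower number here means a stronger inhibitor of growth, a higher number a weaker inhibitor of growth), are as follows.
- compound 1 (`c1cc(NC2=NCCO2)cc(OC2CCCCCC2)c1`) (14800 nM)
- compound 2 (`c1ccc(COc2ccc(NC3=NCCO3)cc2)cc1`) (11100 nM)

Compound 1 shares its place with compound 2, the two values lying within the usual scatter of each other. Compound 3 (`O=C(CCl)NC(=O)Nc1cccc(OC2CCCCCC2)c1`) has not yet been measured. It departs from compound 1 by one change (a group of 7 heavy atoms (3 carbon, 1 nitrogen, 2 oxygen, 1 chlorine; no ring) in place of a group of 5 heavy atoms (3 carbon, 1 nitrogen, 1 oxygen; one five-membered non-aromatic ring with 2 hetero atoms), on a nitrogen on an aromatic ring): the five-membered non-aromatic ring gives way to ((chloromethyl)carbonyl)carbamoyl, on a nitrogen on an aromatic ring. Within the data shown here, no two measured compounds differ in one place, so no measured step is available to scale this change. The expectation therefore rests on the structural change alone and stays loose: a moderate move toward a lower number in this assay is expected. The expected step is (a 2.1-fold lower number from compound 1 to compound 3 (0.33 log units; beyond the scatter)). For compound 3 the estimated value is (7000 nM), with an expected range from (2000 nM) to (25000 nM).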

Compound 3, concentration for 50% growth inhibition: 7200 nM
Estimate against measurement, compound 3: 1.0-fold (0.01 log units) below; measured number inside the range.
By their numbers in this assay, from the lowest: compounds 3, 2 and 1 (each within the scatter of the next, the first and the last beyond it).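

Among these compounds, at this place, on a nitrogen on an aromatic ring, the five-membered non-aromatic ring is not required for growth inhibition: in this assay the open ((chloromethyl)carbonyl)carbamoyl chain is tolerated, giving a 2.1-fold lower number from compound 1 to compound 3 (0.31 log units; beyond the scatter) as the first readable step. The step is modest but beyond the scatter, so on the core of compound 1 this replacement changes the number measurably and does not weaken inhibition. Nothing at hand bears on what lies behind this step.

From the compounds shown here alone, whether the chlorine matters remains open: a plain acetyl or a bromoacetyl group at the end of the chain would separate its contribution from that of the rest of the chain. Going by these compounds, it is also open whether the same replacement carries over to the core of compound 2.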